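Swapping a pyrimidine for dichlorophenyl on a piperazine amide

This account rests on a few compounds, and the source may have more. Where it says the series, first, only, none or still open, it means among the compounds named here.

Compound 2 `O=C(NCCCN1CCN(c2ncccn2)CC1)c1cccc2ccccc12` was tested in an assay on HEK293 cells for inhibition of sodium-dependent dopamine transporter (Homo sapiens), read by scintillation counting (a higher number here means a weaker inhibitor, a lower number a stronger inhibitor), and compound 2 gives > 10000 nM, which is a limit of the assay rather than a number. Compound 1 `O=C(NCCCN1CCN(c2cccc(Cl)c2Cl)CC1)c1cc(Cl)cc(Cl)c1` likewise reaches only a limit, giving > 10000 nM in this assay. Both values therefore sit at the limit of > 10000 nM in this assay, at which 2 of the 2 values shown sit. Compound 3 `O=C(NCCCN1CCN(c2cccc(Cl)c2Cl)CC1)c1cccc2ccccc12` differs from compound 2 by 2,3-dichlorophenyl in place of pyrimidin-2-yl on an amine nitrogen in a ring. Among the compounds with values here, no measured step between these compounds exists, so the change from compound 2 to compound 3 is expected to move potency by a number no higher from compound 2 to compound 3 (the limit leaves the size open), not beyond the scatter, with a fair chance that only a limit is reported again. Compound 3 is estimated at 10000 nM, between 2500 nM and 40000 nM.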

Compound 3, half-maximal inhibitory concentration: > 10000 nM
Compound 3: only a limit was reported; the forecaster's own chance of this, stated with the estimate: 60%; the middle value lies on the limit itself.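

Compound 3 gives > 10000 nM in this assay, again a limit, so the steps to it from compound 1 and compound 2 cannot be read: the limit of > 10000 nM in this assay, at which 3 of the 3 values shown sit. The compounds shown leave open whether either change affects potency, and how strongly any of the three inhibits the transporter.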